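The source may report more compounds than this note shows. Statements on the series, on what has been measured and on what is new or still open speak of the compounds shown alone.

Three compounds share one core and differ only in the substituent on the benzoyl ring. Compound 1 `CCN(Cc1ccc2nc(C)[nH]c(=O)c2c1)c1ccc(C(=O)N[C@@H](CCC(=O)O)C(=O)O)c(C)c1` carries a methyl there and gives 320 nM in an assay on isolated protein for inhibition of Thymidylate synthase (Mus musculus); a higher number here means a weaker inhibitor, a lower number a stronger inhibitor. Compound 2 `CCN(Cc1ccc2nc(C)[nH]c(=O)c2c1)c1ccc(C(=O)N[C@@H](CCC(=O)O)C(=O)O)c(F)c1` carries a fluoro and gives 45 nM in this assay; compound 3 `CCN(Cc1ccc2nc(C)[nH]c(=O)c2c1)c1ccc(C(=O)N[C@@H](CCC(=O)O)C(=O)O)c(Cl)c1` carries a chloro and gives 120 nM. Compound 2 therefore stands lowest of the three: the step of a 7.1-fold lower number from compound 1 to compound 2 (0.85 log units; beyond the scatter) and the step of a 2.7-fold higher number from compound 2 to compound 3 (0.43 log units; beyond the scatter) both lie beyond the scatter, as does a 2.7-fold lower number from compound 1 to compound 3 (0.43 log units; beyond the scatter).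

Compound 4 `C=CCN(Cc1ccc2nc(C)[nH]c(=O)c2c1)c1ccc(C(=O)N[C@@H](CCC(=O)O)C(=O)O)c(F)c1` leaves the fluoro in place and alters the chain on the nitrogen instead: vinyl in place of methyl on a saturated chain carbon bound to a nitrogen on an aromatic ring. None of the three measured steps touches that chain; each of them concerns only the aromatic substituent, so they give no direct guide to this change. For the measured compounds named here, with no step in hand that bears on it, the reasonable expectation is that the number in this assay moves little, in no preferred direction, and that the step of no change at the digits printed from compound 2 to compound 4 (within the scatter) stays within the scatter. Compound 4 is accordingly estimated at 45 nM, with a range from 18 nM to 110 nM.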

Compound 4, half-maximal inhibitory concentration: 76 nM
Beside the measured number, compound 4's estimate is 1.7-fold (0.23 log units) below it; low and high end bracket the measured number.
By their numbers in this assay, from the lowest: compounds 2, 4 and 3 (each within the scatter of the next, the first and the last beyond it); then compound 1.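

With the fluoro held in place, the ethyl on the nitrogen gives way to allyl, and this yields a 1.7-fold higher number from compound 2 to compound 4 (0.23 log units; within the scatter) in this assay. For the compounds shown here, this is the first reading on the chain, since all earlier steps concerned only the aromatic substituent, and it shows that vinyl in place of methyl at this place, which adds one heavy atom and a double bond outside aromatic rings, produces no difference that can be told from the scatter. Nothing shown here offers an explanation for this result, so the reading stands as an observation about a single pair.

The compounds shown leave open how far this tolerance extends along the chain, for instance whether a longer chain such as butyl, a propargyl group, or a chain ending in an amine, a hydroxyl or a carboxylic acid would also stay within the scatter of compound 2. They also leave open whether allyl in place of ethyl would give a similar step with the methyl or the chloro as the aromatic substituent.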